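Methyl to ethyl: a small change to compound 2

This account rests on a few compounds, and the source may have more. Where it says the series, first, only, none or still open, it means among the compounds named here.

In a functional assay on PANC-1 cells (Homo sapiens) for cytotoxicity, read by MTT assay, with a stated time of 72 h (on this read-out lower numbers stand for stronger inhibition and higher numbers for weaker inhibition), compound 1 `CN1C/C(=C\c2ccccc2F)C(=O)/C(=C/c2ccccc2F)C1` gives 2200 nM and compound 2 `CN1C/C(=C\c2cc(F)c(F)cc2F)C(=O)/C(=C/c2cc(F)c(F)cc2F)C1` gives 1600 nM and these two values lie within the scatter of each other. Compound 3 `CCN1C/C(=C\c2cc(F)c(F)cc2F)C(=O)/C(=C/c2cc(F)c(F)cc2F)C1` is still unmeasured. It differs from compound 2 by methyl in place of hydrogen on a saturated chain carbon bound to an amine nitrogen in a ring in the form of a methyl in place of hydrogen on a saturated chain carbon bound to an amine nitrogen in a ring, which turns methyl to ethyl. Within the data shown here, with compound 2 at 1600 nM and no measured pair showing this change, the expected no change at the digits printed from compound 2 to compound 3 (within the scatter) stays within the scatter in this assay with no favoured direction. For compound 3 the estimated value is 1600 nM (range 650 nM to 4000 nM).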

Compound 3, half-maximal inhibitory concentration: 830 nM
The estimate for compound 3 lay 1.9-fold (0.29 log units) above the measured number; low and high end bracket the measured number.
By their numbers in this assay, from the lowest: compounds 3, 2 and 1 (each within the scatter of the next, the first and the last beyond it).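

Among these compounds, replacing methyl with ethyl, a methyl in place of hydrogen on a saturated chain carbon bound to an amine nitrogen in a ring, gives a 1.9-fold lower number from compound 2 to compound 3 (0.29 log units; within the scatter) and is the first look at this position, since compound 1 and compound 2 both carry methyl there. Here the position accepts the added carbon with no shift beyond the scatter. No measurement available explains the step. As far as these compounds go, whether a longer chain, such as propyl or butyl, or a benzyl group at this position would move the number beyond the scatter remains open.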